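Extending the amine side chain in a three-compound series

The source may hold more compounds than are shown below. What is called first, only, known or untested is meant among the compounds shown, and "the series" means these compounds.

Compound 1 `CCCCCOc1c(-c2cc(OC)c(OC)c(OC)c2)oc2ccccc2c1=O`: 22200 nM
Compound 2 `CCCCCCOc1c(-c2cc(OC)c(OC)c(OC)c2)oc2ccccc2c1=O`: 29200 nM
Compound 3 `CCCN(CCC)CCCOc1c(-c2cc(OC)c(OC)c(OC)c2)oc2ccccc2c1=O`: 16800 nM

These values come from a functional assay on PC-3 cells (Homo sapiens) for antiproliferative activity, read by WST assay, with a stated time of 3 days; on this read-out lower numbers stand for stronger inhibition and higher numbers for weaker inhibition. Compound 3 is the only one of the three that carries an amine, yet its number does not separate from the other two. The comparisons are a 1.3-fold lower number from compound 1 to compound 3 (0.12 log units; within the scatter) and a 1.7-fold lower number from compound 2 to compound 3 (0.24 log units; within the scatter).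

The next compound, compound 4 `CCCCCN(CCCCC)CCCCOc1c(-c2cc(OC)c(OC)c(OC)c2)oc2ccccc2c1=O`, has not yet been measured. Its structural change is (dipentylamino)methyl in place of dipropylamino on a saturated chain carbon, three bonds along the chain from an oxygen on an aromatic ring. Like the group it replaces, the entering group has no ring and no net charge.

Going by the values given here, three measured steps bear on this change. The two above put dipropylamino in place of ethyl or propyl at this same place, and the third, which lengthens the plain chain, is a 1.3-fold higher number from compound 1 to compound 2 (0.12 log units; within the scatter). None of them passes the scatter. Among the compounds with values here, only three compounds support this picture, and none of them carries a group as large as the one in compound 4, so the range must stay wide. No clear shift is therefore expected in this assay. The expected step, which is only an estimate, is a 1.3-fold lower number from compound 3 to compound 4 (0.11 log units; within the scatter). Compound 4 is estimated at 13000 nM, with an expected range from 4500 nM to 32000 nM.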

Compound 4, half-maximal inhibitory concentration: 7900 nM
The estimate for compound 4 lay 1.6-fold (0.22 log units) above the measured number; low and high end bracket the measured number.
By their numbers in this assay, from the lowest: compound 4; then compounds 3, 1 and 2 (each within the scatter of the next).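

Going by these compounds alone, at this position, on a saturated chain carbon three bonds along the chain from an oxygen on an aromatic ring, the earlier changes stayed within the scatter, but here the entering (dipentylamino)methyl group gives the first step beyond it in this assay, with a 2.1-fold lower number from compound 3 to compound 4 (0.33 log units; beyond the scatter) as the dipropylamino group is replaced. The separation from the two compounds without an amine is wider, with a 3.7-fold lower number from compound 2 to compound 4 (0.57 log units; beyond the scatter) and a 2.8-fold lower number from compound 1 to compound 4 (0.45 log units; beyond the scatter) on the same read-out, which gives compound 4 the lowest number of the four, although all three steps are modest and the number remains in the same broad range. Nothing available here explains why the larger amine side chain goes with this lower number.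

This single step lengthens the link to the nitrogen and also replaces the propyl chains on that nitrogen with pentyl chains, so the compounds shown cannot say which of the two changes matters more. A dibutylamino group, a dihexylamino group or a ring amine such as piperidine could show whether the numbers keep falling as the amine side chain grows or whether the trend stops at some size.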